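The source may report more compounds than this note shows. Statements on the series, on what has been measured and on what is new or still open speak of the compounds shown alone.

Measured compounds in an ADME assay on HEL cells (Homo sapiens) for cytotoxicity, read by microscopy; on this read-out lower numbers stand for higher toxicity in this test and higher numbers for lower toxicity in this test:
compound 1, `O=c1[nH]c(=O)n([C@H]2C[C@H](O)[C@@H](CO)O2)cc1C#CC#Cc1ccccc1`, gives 100000 nM.
compound 2, `O=c1[nH]c(=O)n([C@H]2C[C@H](O)[C@@H](CO)O2)cc1C#CC#Cc1ccccn1`, gives a limit of this assay, > 20000 nM.

Compound 1 holds the only number shown in this assay; the one further value is a limit rather than a number. As far as these compounds go, because of the limit (the limit of > 20000 nM in this assay, at which 1 of the 2 values shown sits), the step that the limit leaves unreadable from compound 1 to compound 2 cannot be read, and its size stays unknown.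

Compound 3, `O=c1[nH]c(=O)n([C@H]2C[C@H](O)[C@@H](CO)O2)cc1C#CC#CCC1CCCC1`, differs from compound 1 by cyclopentylmethyl in place of phenyl on a triple-bonded carbon. Among the measured compounds shown here, no measured step bears on this change: the single step in this assay is unreadable and concerns a different replacement, so nothing here speaks for a move in either direction. The expectation for compound 3 therefore rests on compound 1 alone, which gives 100000 nM, and is a step of no size beyond the scatter, no change at the digits printed from compound 1 to compound 3 (within the scatter). Compound 3 is accordingly estimated at 100000 nM in this assay, with a range from 30000 nM to 200000 nM, and it may well be reported only as a limit.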

Compound 3, minimum cytotoxic concentration in the HEL assay: > 100000 nM
Compound 3: only a limit was reported (the forecaster's own chance of this, stated with the estimate: 40%); the middle value lies on the limit itself.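

In the HEL assay, cyclopentylmethyl in place of phenyl on a triple-bonded carbon gives a number no lower from compound 1 to compound 3 (the limit leaves the size open), so replacing the six-membered aromatic ring with a five-membered non-aromatic ring of carbon only brought no fall in this number; the steps that involve compound 2 cannot be read. In a physicochemical assay for lipophilicity (on this read-out higher numbers stand for higher lipophilicity and lower numbers for lower lipophilicity), compound 1 gives 0.96 and compound 3 gives 1.43. In the physicochemical assay the same change reads as a number 0.47 log units higher from compound 1 to compound 3 (beyond the scatter), so at this position the partition coefficient moved beyond the scatter, which no earlier compound had shown, while the number in the HEL assay did not fall.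

As far as these compounds go, how large the step in the HEL assay really is stays open, and so does any order between the two compounds that carry only limits there. Also open, from the compounds shown here alone, is how an amine or a carboxylic acid on this triple-bonded carbon, or a longer chain in place of cyclopentylmethyl, would read in the HEL assay and in the physicochemical assay.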